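The compounds below may be only part of what the source reports. "The series", "measured", "known", "first", "only" and "open" are said of these compounds alone.

Working notes on the series in a functional assay on HepG2 cells (Homo sapiens) for cytotoxicity, read by MTT assay, with a stated time of 48 h; on this read-out higher numbers stand for weaker inhibition and lower numbers for stronger inhibition.

Compound 1 `FC(F)=C(F)CCSc1nccs1` is the parent of the set. In this assay compound 1 gives only a limit of the assay, > 120000 nM. Compound 2 `FC(F)=C(F)CCSc1ncc(-c2ccncc2)s1` carries pyridin-4-yl on the shared core; in this assay compound 2 also gives only a limit, > 120000 nM. Compound 3 `FC(F)(Cl)C(F)(Cl)CCSc1nc2ccccc2s1` is the third measured member; in this assay compound 3 likewise gives only a limit, > 120000 nM. Going by the values given here, the one single-point step, a step that the two limits leave unreadable from compound 1 to compound 2, cannot be read because the limit of > 120000 nM in this assay, at which 3 of the 3 values shown sit, holds both of its ends.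

Compound 4 `FC(F)=C(F)CCSc1ncc(Cl)s1` is not yet measured. It differs from compound 2 by chloro in place of pyridin-4-yl on an aromatic carbon. Among the compounds with values here, no measured step bears on this change with a readable size, and no measured compound of the series has yet given a number below the limit. The expectation for compound 4 is therefore that the step that the limit leaves unreadable from compound 2 to compound 4 is none beyond the scatter, and that compound 4 is expected at about 150000 nM, within 60000 nM to 400000 nM, most probably again reported only as a limit.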

Compound 4, half-maximal inhibitory concentration: > 120000 nM
Compound 4: no number, only a limit; the forecaster's own chance of this, stated with the estimate: 85%; the middle value lies beyond the limit too.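

No step from compound 1 or compound 2 to compound 4 can be read, because both ends of each step sit at one limit: the limit of > 120000 nM in this assay, at which 4 of the 4 values shown sit.

The compounds shown leave open whether any change on the shared core gives a number in this assay rather than a limit.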